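The source may hold more compounds than are shown below. What is called first, only, known or untested is meant among the compounds shown, and "the series" means these compounds.

Of the compounds shown here, three bearing the same core have been tested in a functional assay on MCF7 cells (Homo sapiens) for antiproliferative activity; a lower number here means a stronger inhibitor, a higher number a weaker inhibitor. Compound 1 `C=CCCCn1c(Cc2cc(OC)c(OC)c(OC)c2)nc2c(N)nc(F)nc21` gives 44700 nM. Compound 2 `CCCCn1c(Cc2c(Br)c(OC)c(OC)c(OC)c2Br)nc2c(N)ncnc21` gives 30200 nM, and compound 3 `COc1cc(Cc2nc3c(N)ncnc3n2CC2CC2)cc(OC)c1OC` gives 75900 nM. Compound 1 sits with compound 2 on one side and compound 3 on the other, but neither gap is beyond the scatter of repeated measurements, so the three numbers cannot be told apart in this assay.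

The next compound, compound 4 `C=CCCn1c(Cc2cc(OC)c(OC)c(OC)c2)nc2c(N)nc(F)nc21`, has not been measured. Compared with compound 1 it carries one change: vinyl in place of allyl on a saturated chain carbon, two bonds along the chain from an aromatic nitrogen. The chain on the nitrogen is thus shortened by one carbon while keeping its double bond.

Among the compounds with values here, no pair of measured compounds differs in only one place, so no step in this assay is known. Since the three values of compounds 1, 2 and 3 in this assay all lie within the scatter of one another despite different groups on that nitrogen, compound 4 is expected to stay near compound 1, with a step from a 1.1-fold higher number from compound 1 to compound 4 (0.05 log units; within the scatter) that is expected to be small and not beyond the scatter. Compound 4 is estimated to give 50000 nM, in a range from 20000 nM to 125000 nM.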

Compound 4, half-maximal inhibitory concentration: 33100 nM
For compound 4 the middle estimate is 1.5-fold (0.18 log units) above the measured one; the range from low to high includes it.
By their numbers in this assay, from the lowest: compounds 2, 4, 1 and 3 (each within the scatter of the next, the first and the last beyond it).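

In this assay, within the data shown here, the change of pent-4-en-1-yl to but-3-en-1-yl on the aromatic nitrogen, with the rest of the molecule held constant, gives a 1.4-fold lower number from compound 1 to compound 4 (0.13 log units; within the scatter), the only step here between compounds that differ in one place. At this position, therefore, the two chains cannot be told apart, and removing one carbon from the chain while keeping its double bond has no effect that this assay can resolve. No other measurement bears on this step.

The compounds shown leave open whether an amine, a carboxylic acid or a much longer chain at the end of the group on that nitrogen would give a step beyond the scatter. They also leave open whether the same shortening would read alike in a compound carrying the two bromine atoms of compound 2.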